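3-Chlorophenyl in place of 3-methoxyphenyl on the piperazine

The compounds below may be only part of what the source reports. "The series", "measured", "known", "first", "only" and "open" are said of these compounds alone.

Compound 3 `COc1cccc(N2CCN(C(=O)c3oc(C)nc3-c3ccccc3)CC2)c1` gives 34.8 nM in a functional assay on HL-60 cells (Homo sapiens) for inhibition, read by MTT assay, with a stated time of 72 h (a higher number here means a weaker inhibitor, a lower number a stronger inhibitor), the lowest of the two numbers in hand. Compound 1 `Cc1nc(-c2ccccc2)c(C(=O)N2CCN(c3cccc(C(N)=O)c3)CC2)o1` gives 71 nM in this assay. For compound 2 `Cc1nc(-c2ccccc2)c(C(=O)N2CCN(c3ccc(C(F)(F)F)cc3)CC2)o1` this assay reports only a limit, > 1000 nM. The measured steps are a 2.0-fold lower number from compound 1 to compound 3 (0.31 log units; beyond the scatter), an at least 14-fold higher number from compound 1 to compound 2 (1.14 log units; beyond the scatter) and an at least 28-fold lower number from compound 2 to compound 3 (1.45 log units; beyond the scatter); the last two rest on the limit (the limit of > 1000 nM in this assay, at which 1 of the 3 values shown sits).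

Compound 4 `Cc1nc(-c2ccccc2)c(C(=O)N2CCN(c3cccc(Cl)c3)CC2)o1` differs from compound 3 in one place: chloro in place of methoxy on an aromatic carbon. The step from compound 1 to compound 3 is the closest guide, since it also swaps one group at that aromatic carbon and was modest. The large steps to and from compound 2 involve 4-(trifluoromethyl)phenyl, a different group in a different place, so they bear only loosely. Going by the values given here, no chloro analogue has been measured, so in this assay a step within the scatter is expected for compound 4, a 1.4-fold higher number from compound 3 to compound 4 (0.16 log units; within the scatter). Compound 4 is estimated at 50 nM, with the expected range running from 18 nM to 160 nM.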

Compound 4, half-maximal inhibitory concentration: 39.2 nM
Compound 4: middle estimate off by 1.3-fold (0.11 log units), on the high side; measured number inside the range.
By their numbers in this assay, from the lowest: compounds 3, 4 and 1 (each within the scatter of the next, the first and the last beyond it). At a limit, above all of these: compound 2.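

Chloro and methoxy cannot be told apart on this aromatic carbon in this assay, a 1.1-fold higher number from compound 3 to compound 4 (0.05 log units; within the scatter), and chloro also stays within the scatter of carbamoyl, a 1.8-fold lower number from compound 1 to compound 4 (0.26 log units; within the scatter), although the methoxy step, a 2.0-fold lower number from compound 1 to compound 3 (0.31 log units; beyond the scatter), lies just beyond it, so that earlier step gives no clear ranking of the groups at this position. Compound 2 is known only as a limit: the limit of > 1000 nM in this assay, at which 1 of the 4 values shown sits. Read against that limit, 3-chlorophenyl gives only a bound, an at least 25-fold lower number from compound 2 to compound 4 (1.40 log units; beyond the scatter), and that comparison changes group and place together.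

The compounds shown do not separate the group from its place, a question that 4-chlorophenyl or 3-(trifluoromethyl)phenyl would address. Also open, from the compounds shown here alone, is how a carboxylic acid or an amine would read on this same carbon.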